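Compound 4: Swapping the Group on the Carbonyl

The source may report more compounds than this note shows. Statements on the series, on what has been measured and on what is new or still open speak of the compounds shown alone.

Compound 1 `CCN1CCN(c2cc(C)c3cc(NC(=O)c4ccccc4F)ccc3n2)CC1` gives 32600 nM
Compound 2 `CCN(CC)c1cc(C)c2cc(NC(=O)c3ccc(Cl)c(Cl)c3)ccc2n1` gives > 50000 nM as a limit
Compound 3 `Cc1cc(N(C)C)nc2ccc(NC(=O)c3ccc(Cl)c(Cl)c3)cc12` gives 33300 nM

In a functional assay on MCF7 cells (Homo sapiens) for antiproliferative activity, read by MTT assay, with a stated time of 72 h (a higher number here means a weaker inhibitor, a lower number a stronger inhibitor), compound 1 gives 32600 nM and lies within the scatter of compound 3 at 33300 nM on the same scale. Compound 2 gives > 50000 nM as its reading, and that is a limit and not a number.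

Compound 4 `CCN1CCN(c2cc(C)c3cc(NC(=O)c4ccc5ccccc5n4)ccc3n2)CC1` differs from compound 1 by quinolin-2-yl in place of 2-fluorophenyl on a carbonyl carbon and by nothing else. Going by the values given here, the one measured step runs an at least 1.5-fold lower number from compound 2 to compound 3 (0.17 log units; that floor lies within the scatter) and concerns dimethylamino in place of diethylamino on an aromatic carbon, so it does not touch the group that changes here. Among the compounds with values here, no measured step isolates a change on the carbonyl carbon. Within the data shown here, the only indirect guide is compound 3 at 33300 nM which carries a different group there, along with a different amine, and still stays within the scatter of compound 1. The estimate is a 1.2-fold lower number from compound 1 to compound 4 (0.07 log units; within the scatter) in this assay and so no step beyond the scatter is expected in either direction. For compound 4 the expected value is 28000 nM with an estimated range of 9000 nM to 50000 nM around it.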

Compound 4, half-maximal inhibitory concentration: 7060 nM
For compound 4 the middle estimate is 4.0-fold (0.60 log units) above the measured one, outside the stated range (below it).
By their numbers in this assay, from the lowest: compound 4; then compounds 1 and 3 (each within the scatter of the next). At a limit, above all of these: compound 2.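

In this assay, quinolin-2-yl in place of 2-fluorophenyl on a carbonyl carbon gives a 4.6-fold lower number from compound 1 to compound 4 (0.66 log units; beyond the scatter), so a change at this position alone, with the amine and the shared core left as they are, moves the number beyond the scatter. Going by these compounds alone, the one earlier step concerned the amine and showed no such move, which makes this the first evidence in the set that the group on the carbonyl carbon has a bearing on antiproliferative activity in these cells. The swap brings in a ring with a nitrogen and a hydrogen-bond acceptor that 2-fluorophenyl lacks and removes the fluorine, but nothing at hand explains the step.

The compounds shown leave open whether the step follows the added ring or the ring nitrogen of quinolin-2-yl, a question that a naphthyl or a pyridyl group on the carbonyl carbon would address. They also leave open whether quinolin-2-yl would act in the same way with the dimethylamino group of compound 3 in place of the amine of compound 4.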